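The source may hold more compounds than are shown below. What is called first, only, known or untested is meant among the compounds shown, and "the series" means these compounds.

In a functional assay on DU-145 cells (Homo sapiens) for inhibition, read by trypan blue exclusion, with a stated time of 96 h (a higher number here means a weaker inhibitor of growth, a lower number a stronger inhibitor of growth), three compounds have already been measured. Compound 1 `Cc1ccc(CS/C(=C/c2ccc(N(C)C)cc2)C(=O)c2ccc(Cl)cc2)cc1` gives only the limit > 100000 nM. Compound 2 `Cc1ccc(CS/C(=C/c2ccccc2F)C(=O)c2ccc(Cl)cc2)cc1` gives 10000 nM. Compound 3 `O=C(/C(=C\c1c(O)cc(O)cc1O)Sc1ccc(Br)cc1)c1ccc(Cl)cc1` gives 50000 nM, the higher of the two values that are numbers rather than limits. Within the data shown here, the one measured step, an at least 10-fold lower number from compound 1 to compound 2 (1.00 log units; beyond the scatter), changes the group on the double-bonded chain carbon, not the group on the sulfur. Compound 4 `Cc1ccc(CS/C(=C/c2c(O)cc(O)cc2O)C(=O)c2ccc(Cl)cc2)cc1` keeps the core of compound 3 and differs only as 4-methylbenzyl in place of 4-bromophenyl on a sulfur. Among the measured compounds shown here, no measured step touches the sulfur, so no direct guide exists, and as the limit of > 100000 nM in this assay, at which 1 of the 3 values shown sits, shows, one value is only a limit. Compound 4 is therefore expected to show a 1.3-fold lower number from compound 3 to compound 4 (0.10 log units; within the scatter). The estimated value for compound 4 is 40000 nM, expected to lie between 10000 nM and 150000 nM.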

Compound 4, concentration for 50% growth inhibition: 50000 nM
The estimate for compound 4 lay 1.3-fold (0.10 log units) below the measured number, and the stated range covers the measured number.
By their numbers in this assay, from the lowest: compound 2; then compounds 3 and 4 (each within the scatter of the next). At a limit, above all of these: compound 1.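

On the sulfur, the first direct test of this position, 4-methylbenzyl and 4-bromophenyl cannot be told apart with the 2,4,6-trihydroxyphenyl group in place: no change at the digits printed from compound 3 to compound 4 (within the scatter). With 4-methylbenzyl held on the sulfur, the group on the double-bonded chain carbon does shift the number, as a 5.0-fold higher number from compound 2 to compound 4 (0.70 log units; beyond the scatter) shows. A third step gives only a floor, an at least 2.0-fold lower number from compound 1 to compound 4 (0.30 log units; that floor lies within the scatter), and the reason is a limit of the assay: the limit of > 100000 nM in this assay, at which 1 of the 4 values shown sits.

Going by these compounds, whether this sulfur swap gives the same result with 2-fluorophenyl in place of 2,4,6-trihydroxyphenyl stays open. So does the effect of an amine or a carboxylic acid on the sulfur.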